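Working notes: nitro in place of methoxy

This account rests on a few compounds, and the source may have more. Where it says the series, first, only, none or still open, it means among the compounds named here.

In a functional assay on NCI-H460 cells (Homo sapiens) for inhibition, read by MTT assay, with a stated time of 24 h, tested at 0.1 ug/mL (on this read-out lower numbers stand for less inhibition of growth and higher numbers for more inhibition of growth at the one concentration tested), compound 1 `O=C(CCCCC(S)CCS)Nc1ccccc1` gives 5.5%, compound 2 `O=C(CCCCC(S)CCS)Nc1ccc(F)cc1` gives 5.64% and compound 3 `COc1ccc(NC(=O)CCCCC(S)CCS)cc1` gives 5.69%, so compound 3 stands level with the other two within the scatter. Compound 4 `O=C(CCCCC(S)CCS)Nc1ccc([N+](=O)[O-])cc1` carries nitro in place of methoxy on an aromatic carbon, para to a large group: nitro in place of methoxy on an aromatic carbon. The relevant steps are a number 0.1 percentage points higher from compound 1 to compound 2 (within the scatter), a number 0.2 percentage points higher from compound 1 to compound 3 (within the scatter) and a number 0.1 percentage points higher from compound 2 to compound 3 (within the scatter), all small and within the scatter. For the measured compounds named here, no nitro compound has been measured, so these steps are only indirect guides. No step beyond the scatter is expected in this assay. The estimated change is a number 0.3 percentage points higher from compound 3 to compound 4 (within the scatter). For compound 4, the expected value is 6%, with an estimated range of 3% to 14%.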

Compound 4, percent growth inhibition at one concentration: 5.69%
For compound 4 the middle estimate is 0.3 percentage points above the measured one; measured number inside the range.
By their numbers in this assay, from the lowest: compounds 1, 2, 3 and 4 (each within the scatter of the next).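

With nitro on this aromatic carbon, para to a large group, this assay shows no change at the digits printed from compound 3 to compound 4 (within the scatter) and a number 0.1 percentage points higher from compound 2 to compound 4 (within the scatter) and a number 0.2 percentage points higher from compound 1 to compound 4 (within the scatter) in this series. Hydrogen, fluoro, methoxy and now nitro at this place are therefore not separated by this read-out at its one concentration. No supporting evidence bears on the reason for this result. Open, going by these compounds, is whether an amine or a carboxylic acid at this place, or a longer chain on the shared core, would give a step beyond the scatter. The behaviour of these compounds at other concentrations also stays open.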